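The source may report more compounds than this note shows. Statements on the series, on what has been measured and on what is new or still open speak of the compounds shown alone.

Compound 1 `Cc1cccc(N2CCn3c2n[nH]c(=O)c3=O)c1C` and compound 2 `Cc1ccc(N2CCn3c2n[nH]c(=O)c3=N)cc1` share one core. In a functional assay on T47D cells (Homo sapiens) for cytotoxicity, with a stated time of 72 h, tested at 10 ug/mL (a higher number here means a stronger effect of the compound at the concentration tested, a lower number a weaker effect), compound 1 gives 21%, while compound 2 gives 0%, the lower of the two numbers, and its gap to compound 1 lies beyond the usual scatter. Compound 3 `N=c1c(=O)[nH]nc2n1CCN2c1ccc(Cl)cc1` has not yet been measured. Its difference from compound 2 is chloro in place of methyl on an aromatic carbon. For the measured compounds named here, no measured pair shows this change, so for compound 3 only a small rise is expected, a step of a number 10 percentage points higher from compound 2 to compound 3 (within the scatter), which may not reach beyond the scatter. Compound 3 is therefore estimated to give 10% in this assay, between 0% and 35%.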

Compound 3, a percentage reported as inhibition, at one concentration (the size of the read-out at that concentration, not a potency): 16%
Compound 3: the middle estimate sits 6 percentage points below what was measured; the measured number falls inside the stated range.
By their numbers in this assay, from the lowest: compound 2; then compounds 3 and 1 (each within the scatter of the next).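

Chloro in place of methyl on an aromatic carbon, para to a large group, gives a number 16 percentage points higher from compound 2 to compound 3 (beyond the scatter) in this assay and so shows that the read-out responds to the group at this position. For the compounds shown here, this is the first step seen at this position, and it is a modest one that rests on a single pair of compounds. Nothing available explains the step.

From the compounds shown here alone, how other groups at this place would read, such as an amine, a methoxy group or a carboxylic acid, stays open. Also open, going by these compounds, is whether the same swap gives a similar step on the core of compound 1.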